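The source may hold more compounds than are shown below. What is called first, only, known or untested is meant among the compounds shown, and "the series" means these compounds.

Compound 1 `Cc1ccc2c(c1)C1CNCC2C1`: 1.6 nM
Compound 2 `CCCn1c(C)nc2cc3c(cc21)C1CNCC3C1`: 0.19 nM
Compound 3 `Fc1cc2c(cc1F)C1CNCC2C1`: 0.28 nM

These three compounds share a core and were tested in an assay on HEK293 cells for binding affinity to Neuronal acetylcholine receptor; alpha4/beta2 (Homo sapiens); on this read-out lower numbers stand for stronger inhibition and higher numbers for weaker inhibition. Compound 1 gives the highest of the three numbers in this assay; compound 3 sits at a lower value and compound 2 lower still, and both of those gaps are beyond the usual scatter. Compound 4 `CC(=O)Nc1ccc2c(c1)C1CNCC2C1` has not been measured yet. It differs from compound 1 in a single place: acetamido in place of methyl on an aromatic carbon. Among the measured compounds shown here, no two measured compounds differ in only one place, so no comparable step exists to guide the expectation. The step of a 1.9-fold higher number from compound 1 to compound 4 (0.27 log units; within the scatter) is expected to be small, a modest move toward a higher number, possibly none beyond the scatter. Compound 4 is estimated at 3 nM, with a range from 0.8 nM to 12 nM.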

Compound 4, inhibition constant: 75 nM
Estimate against measurement, compound 4: 25-fold (1.40 log units) below; measured number outside the range, above it.
By their numbers in this assay, from the lowest: compounds 2 and 3 (each within the scatter of the next); then compound 1; then compound 4.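

In this assay, acetamido in place of methyl on this aromatic carbon gives a 47-fold higher number from compound 1 to compound 4 (1.67 log units; beyond the scatter), the first change in a single place among these compounds. It shows that this position does not treat all groups alike: the number can move far with this one swap. The swap adds heavy atoms, a hydrogen-bond donor and a hydrogen-bond acceptor together, and no available evidence separates their contributions or explains the result. Going by these compounds, whether an amine or an acetyl group on the same carbon would stay close to compound 1 remains open.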